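Swapping a pyrrolidine for a methyl on the oxime ether chain

The source may report more compounds than this note shows. Statements on the series, on what has been measured and on what is new or still open speak of the compounds shown alone.

Measured so far:
- compound 1, `Nc1ncnc(Oc2ccc(NC(=O)C3(C(=O)Nc4ccc(F)cc4)CC3)cc2F)c1/C=N/O`: 2.62
- compound 2, `Nc1ncnc(Oc2ccc(NC(=O)C3(C(=O)Nc4ccc(F)cc4)CC3)cc2F)c1/C=N/OCC(=O)N1CCOCC1`: 2.1
- compound 3, `Nc1ncnc(Oc2ccc(NC(=O)C3(C(=O)Nc4ccc(F)cc4)CC3)cc2F)c1/C=N/OCCCN1CCCC1`: 3.82

These three compounds share one core and differ only in the group on the oxime oxygen. In a physicochemical assay for lipophilicity, using the shake flask method (a higher number here means a more lipophilic compound, a lower number a more polar compound), compound 3 stands highest of the three numbers: a number 1.20 log units higher from compound 1 to compound 3 (beyond the scatter) and a number 1.72 log units higher from compound 2 to compound 3 (beyond the scatter), both beyond the scatter, while a number 0.52 log units lower from compound 1 to compound 2 (beyond the scatter).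

Compound 4, `CCCCO/N=C/c1c(N)ncnc1Oc1ccc(NC(=O)C2(C(=O)Nc3ccc(F)cc3)CC2)cc1F`, has not yet been measured. The change from compound 3 is methyl in place of pyrrolidin-1-yl on a saturated chain carbon, three bonds along the chain from an oxygen. Among the compounds with values here, no measured step swaps exactly this pair of groups. The closest guide is the large rise from compound 1 to compound 3, which shows that lengthening the chain on the oxygen raised the number strongly, and in compound 4 a plain butyl chain keeps that length without the ring nitrogen. A further rise beyond the scatter in this assay is therefore expected, though its size is uncertain, with a number 0.78 log units higher from compound 3 to compound 4 (beyond the scatter) as the estimated step. Compound 4 is thus expected to give about 4.6, with a likely range from 3.9 to 5.3.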

Compound 4, partition coefficient: 4.2
Compound 4: the middle estimate sits 0.40 log units above what was measured; low and high end bracket the measured number.
By their numbers in this assay, from the lowest: compound 2; then compound 1; then compound 3; then compound 4.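

In this assay compound 4 stands highest of the four, and a number 0.38 log units higher from compound 3 to compound 4 (beyond the scatter) shows that the number still rises when methyl takes the place of pyrrolidin-1-yl at this chain position. With a number 1.58 log units higher from compound 1 to compound 4 (beyond the scatter) as well, a butyl chain on the oxime oxygen is enough for a large rise and needs no ring at its end. Compound 2 goes against any rule that every group here raises the number, since a number 2.10 log units higher from compound 2 to compound 4 (beyond the scatter) separates it from the butyl chain, and no measurement at hand explains the size of these steps.

Still open, going by these compounds, is how a longer chain, such as hexyl, would compare with butyl in this assay. A carboxylic acid or a simple dimethylamino group at the chain end is also untested among the compounds shown here.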